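The source may report more compounds than this note shows. Statements on the series, on what has been measured and on what is new or still open speak of the compounds shown alone.

Measured so far:
compound 1, `C=CC1=C(C(=O)Nc2ccc(OCC)cc2)C(c2ccc(F)cc2)OC1` — > 100000 nM
compound 2, `C=CC1=C(C(=O)NCc2ccc(OC)c(OC)c2)C(c2ccc(OC)cc2)OC1` — > 100000 nM

Both results in a functional assay on HeLa cells (Homo sapiens) for cytotoxicity, read by MTT assay, with a stated time of 24 h (on this read-out lower numbers stand for stronger inhibition and higher numbers for weaker inhibition), are limits of the assay, not numbers. For compound 2 the assay gives > 100000 nM, a limit only. For compound 1 it likewise gives > 100000 nM, again a limit. Among the measured compounds shown here, compound 2 therefore cannot be placed on a scale at all: no number exists for it, and the only other value shown is the same limit, so nothing in this assay separates the two compounds; both sit at the limit of > 100000 nM in this assay, at which 2 of the 2 values shown sit.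

Compound 3, `C=CC1=C(C(=O)NCc2ccc(OC)c(OC)c2)C(c2ccc(F)cc2)OC1`, is not yet measured. It differs from compound 2 in one place: fluoro in place of methoxy on an aromatic carbon. The compound that already carries the fluoro group on that ring, compound 1, is also at the limit, which gives no hint of any gain from the exchange.

Expectation for this assay: no step beyond the scatter, with the measurement most likely ending at the same limit, because the limit of > 100000 nM in this assay, at which 2 of the 2 values shown sit, holds both values shown. The expected step that the limit leaves unreadable from compound 2 to compound 3 is set at essentially nothing. Compound 3 is accordingly estimated at 200000 nM, with a range from 100000 nM to 500000 nM.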

Compound 3, half-maximal inhibitory concentration: > 100000 nM
Compound 3: only a limit was reported (the forecaster's own chance of this, stated with the estimate: 90%); the middle value does not contradict the limit.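

No step can be read from compound 2 to compound 3 in this assay, since both results are limits of the assay and not numbers: the limit of > 100000 nM in this assay, at which 3 of the 3 values shown sit.

The compounds shown leave open whether fluoro in place of methoxy has any effect on the read-out, and whether any member of this series gives a true number in this assay.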